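The compounds below may be only part of what the source reports. "The series", "measured", "known", "first", "only" and "open" are said of these compounds alone.

For the measured compounds named here, the three measured members share a single core and are compared in an assay on isolated protein for displacement of a labelled ligand from metabotropic glutamate receptor 5 (Homo sapiens), with a stated time of 60 min, tested at 1 uM; a lower number here means less inhibition, a higher number more inhibition at the concentration tested (going by the name of the read-out). Compound 1 `COc1ccc(S(=O)(=O)c2cnc3cc(Cl)ccc3c2N2CCC(C)CC2)cc1Cl` gives 93% in this assay. Compound 2 `COc1ccc(S(=O)(=O)c2cnc3cc(F)ccc3c2N2CCC(C)CC2)cc1OC` gives 83%, and compound 3 `CC1CCN(c2c(S(=O)(=O)c3ccc(Cl)c(Cl)c3)cnc3ccc(Cl)cc23)CC1` gives 86%. Compound 1 holds the highest of the three numbers, yet its gap to compound 3 and its gap to compound 2 both lie within the usual scatter of repeated measurements, so the three compounds cannot be ordered against one another on these data.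

Compound 4 `Cc1ccc(S(=O)(=O)c2cnc3cc(Cl)ccc3c2N2CCC(C)CC2)cc1` has not yet been measured in this assay. It differs from compound 1 in one place: 4-methylphenyl in place of 3-chloro-4-methoxyphenyl on a sulfonyl sulfur. The group that leaves carries one hydrogen-bond acceptor and a chlorine; the group that enters, 4-methylphenyl, carries neither. Going by the values given here, no step between two measured compounds touches the ring on the sulfonyl sulfur, so no direct comparison shows what such a change does.

Since every measured compound keeps a substituted ring on the sulfonyl sulfur and all three give high numbers in this assay, compound 4 is expected to give a number somewhat lower than that of compound 1, with an estimated step of a number 15 percentage points lower from compound 1 to compound 4 (beyond the scatter). Compound 4 is thus estimated at 78%, with a likely range from 55% to 94%.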

Compound 4, a percentage reported as inhibition, at one concentration (the size of the read-out at that concentration, not a potency): 94%
Beside the measured number, compound 4's estimate is 16 percentage points below it, and the stated range covers the measured number.
By their numbers in this assay, from the lowest: compounds 2, 3, 1 and 4 (each within the scatter of the next, the first and the last beyond it).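

In this assay, for the compounds shown here, the change to 4-methylphenyl in place of 3-chloro-4-methoxyphenyl on a sulfonyl sulfur gives a number 1 percentage points higher from compound 1 to compound 4 (within the scatter), the first direct comparison that touches this ring. The result shows that, at the concentration tested, a high number on this position needs neither the chlorine nor the hydrogen-bond acceptor of the group that leaves, since compound 4, with a ring carrying neither, stays level with compound 1. The data offer no measurement that could explain why the number holds across this change.

The read-out is the size of the inhibition at a single concentration, so it does not show whether compound 1 and compound 4 would also match in potency. As far as these compounds go, it also remains open whether the position would keep its high number with a ring bearing an amine or a carboxylic acid in place of the methyl group, or with an unsubstituted phenyl ring on the sulfonyl sulfur.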